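A few compounds are considered here, and "the series" means these few. Any claim that something is new, unique, unknown or untested is made for them only; others in the source may bear on it.

Compound 1: `COc1ccc(S(=O)(=O)c2cnc3c(F)cccc3c2-c2cccc(F)c2)cc1` — 3.03 mL/min
Compound 2: `COc1cccc(-c2c(S(=O)(=O)c3cc(F)cc(F)c3)cnc3c(F)cccc23)c1` — 2.76 mL/min
Compound 3: `COc1cccc(-c2c(S(=O)(=O)c3cc(Cl)cc(Cl)c3)cnc3c(F)cccc23)c1` — 2.31 mL/min

All three were run in an ADME assay on microsomes from liver (Homo sapiens) for metabolic stability, tested at 2.5 uM; on this read-out lower numbers stand for slow clearance and higher numbers for fast clearance. Compound 3 gives the lowest of the three numbers, yet its gap to compound 2 and to compound 1 each sit within the scatter, so the three cannot be told apart on this read-out. Within the data shown here, the single measured change at the same place, a 1.2-fold lower number from compound 2 to compound 3 (0.08 log units; within the scatter), is also within the scatter.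

Compound 4, `COc1ccc(S(=O)(=O)c2cnc3c(F)cccc3c2-c2cccc(OC)c2)cc1`, has not yet been measured in this assay. It differs from compound 3 in one place: 4-methoxyphenyl in place of 3,5-dichlorophenyl on a sulfonyl sulfur. Among the measured compounds shown here, only the step from compound 2 to compound 3 touches the group on the sulfonyl sulfur, and it barely moved the number. Compound 1, which already carries a 4-methoxyphenyl on its sulfonyl sulfur, gives 3.03 mL/min, close to the others. Therefore a step no larger than the scatter is expected for compound 4, a 1.3-fold higher number from compound 3 to compound 4 (0.11 log units; within the scatter). Compound 4 is thus estimated at 3 mL/min, with a range from 1.8 mL/min to 5 mL/min.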

Compound 4, intrinsic clearance in a liver preparation (reported as CLH), per the amount of preparation that the assay uses: 2.87 mL/min
Estimate against measurement, compound 4: 1.0-fold (0.02 log units) above; low and high end bracket the measured number.
By their numbers in this assay, from the lowest: compounds 3, 2, 4 and 1 (each within the scatter of the next).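

In this assay, the group on the sulfonyl sulfur has now been varied three ways, and 4-methoxyphenyl gives a 1.2-fold higher number from compound 3 to compound 4 (0.09 log units; within the scatter) and a 1.0-fold higher number from compound 2 to compound 4 (0.02 log units; within the scatter), so it cannot be told apart from either 3,5-dichlorophenyl or 3,5-difluorophenyl at this place. A second place is now tested as well: methoxy in place of fluoro on an aromatic carbon gives a 1.1-fold lower number from compound 1 to compound 4 (0.02 log units; within the scatter), so this change also stays within the scatter. No available data explain why neither kind of change separates these compounds.

On these data alone, every group on the sulfonyl sulfur here is a substituted phenyl ring, so it remains open whether a piperidine ring or a phenyl ring carrying a carboxylic acid would shift the number beyond the scatter. As far as these compounds go, whether a nitrile or an amine in place of the methoxy would do so is equally open.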